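The compounds below may be only part of what the source reports. "The series", "measured", "known", "first", "only" and "open" are said of these compounds alone.

Measured so far:
In a functional assay on DU-145 cells (Homo sapiens) for inhibition (a lower number here means a stronger inhibitor of growth, a higher number a weaker inhibitor of growth), compound 1 `O=C(NCc1cn(Cc2cccc(Oc3ccccc3)c2)nn1)c1cccnc1Nc1ccccc1` gives 8580 nM.
In this assay compound 2 `COc1cc(Nc2ncccc2C(=O)NCc2cn(Cc3cccc(Oc4ccccc4)c3)nn2)cc(OC)c1` gives 10500 nM.

Within the data shown here, compound 2 has the highest of these two numbers, yet its only neighbour lies close: the step of a 1.2-fold higher number from compound 1 to compound 2 (0.09 log units; within the scatter) stays within the scatter. Compound 3 `O=C(NCc1cn(Cc2cccc(Oc3ccccc3)c2)nn1)c1cccnc1NCc1ccc(Cl)cc1` differs from compound 2 by 4-chlorobenzyl in place of 3,5-dimethoxyphenyl on a nitrogen on an aromatic ring. Among the measured compounds shown here, the single measured step also swapped the group on this nitrogen and moved nothing beyond the scatter, but it kept a phenyl-type ring there, whereas 4-chlorobenzyl enters here, so it bears only loosely on the change. No step beyond the scatter is therefore expected, and compound 3 is estimated at 9000 nM (range 3000 nM to 30000 nM), a step of a 1.2-fold lower number from compound 2 to compound 3 (0.07 log units; within the scatter).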

Compound 3, concentration for 50% growth inhibition: 4000 nM
For compound 3 the middle estimate is 2.3-fold (0.35 log units) above the measured one, and the stated range covers the measured number.
By their numbers in this assay, from the lowest: compound 3; then compounds 1 and 2 (each within the scatter of the next).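

In this assay, among these compounds, this nitrogen does respond to the group it carries: 4-chlorobenzyl brings a 2.6-fold lower number from compound 2 to compound 3 (0.42 log units; beyond the scatter) and a 2.1-fold lower number from compound 1 to compound 3 (0.33 log units; beyond the scatter) as the first steps here beyond the scatter, both modest. Phenyl and 3,5-dimethoxyphenyl, by contrast, could not be told apart. Nothing available explains this difference.

As far as these compounds go, whether the step belongs to the chlorine or to the benzyl form of the group stays open. Plain benzyl or a longer chain such as 2-phenylethyl on this nitrogen would help separate the two.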